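The compounds below may be only part of what the source reports. "The series", "measured", "known", "first", "only" and "open" are said of these compounds alone.

Measured compounds:
compound 1 `C#Cc1cccc(Nc2ncnc3cc(OC)c(OCCCCC(=O)Nc4ccc(S(N)(=O)=O)cc4)cc23)c1`, 17700 nM
compound 2 `COc1cc2ncnc(Nc3ccc(C)cc3)c2cc1OCCCCC(=O)Nc1ccc(S(N)(=O)=O)cc1`, 35500 nM
compound 3 `NS(=O)(=O)c1ccc(NC(=S)Nc2ccc3ncnc(Nc4ccc(Cl)c(C(F)(F)F)c4)c3c2)cc1`, 18200 nM

In a functional assay on A-431 cells (Homo sapiens) for antiproliferative activity, read by MTT assay, with a stated time of 72 h (a lower number here means a stronger inhibitor, a higher number a weaker inhibitor), compound 3 sits among the three numbers with compound 1 as its nearest neighbour and compound 2 as its furthest, both gaps within the scatter. Compound 4 `Cc1ccc(Nc2ncnc3ccc(NC(=S)Nc4ccc(S(N)(=O)=O)cc4)cc23)cc1` differs from compound 3 by 4-methylphenyl in place of 4-chloro-3-(trifluoromethyl)phenyl on a nitrogen on an aromatic ring. Among the measured compounds shown here, the one measured step that bears on this, a 2.0-fold higher number from compound 1 to compound 2 (0.30 log units; within the scatter), also exchanges the group on that nitrogen for 4-methylphenyl and stayed within the scatter, so in this assay no step beyond the scatter is expected from compound 3 to compound 4, perhaps a slight drift toward a higher number. Compound 4 is therefore estimated at 25000 nM, between 10000 nM and 60000 nM. The expected step is a 1.4-fold higher number from compound 3 to compound 4 (0.14 log units; within the scatter).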

Compound 4, half-maximal inhibitory concentration: 40000 nM
For compound 4 the middle estimate is 1.6-fold (0.20 log units) below the measured one; low and high end bracket the measured number.
By their numbers in this assay, from the lowest: compounds 1, 3, 2 and 4 (each within the scatter of the next, the first and the last beyond it).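

In this assay, the change to 4-methylphenyl gives a 2.2-fold higher number from compound 3 to compound 4 (0.34 log units; beyond the scatter), so a replacement on this nitrogen can carry a modest step past the scatter. The earlier step, a 2.0-fold higher number from compound 1 to compound 2 (0.30 log units; within the scatter), brought in the same group but started from 3-ethynylphenyl and a different remainder of the molecule. Nothing measured here gives a reason for the size of the new step. Still open, going by these compounds, is how a phenyl ring carrying an amine or a carboxylic acid would read at this nitrogen, and whether 4-chloro-3-(trifluoromethyl)phenyl would give a similar step on the core of compound 1.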